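This account rests on a few compounds, and the source may have more. Where it says the series, first, only, none or still open, it means among the compounds named here.

Measured compounds in the series so far:

- Compound 1, `O=C(Nc1ccc(Oc2ccnc3[nH]ccc23)cc1)c1cn(-c2ccccc2)c2ccccc2c1=O`: in a functional assay on A549 cells (Homo sapiens) for inhibition, read by MTT assay, with a stated time of 72 h (a lower number here means a stronger inhibitor, a higher number a weaker inhibitor), compound 1 gives 1030 nM.
- Compound 2, `O=C(Nc1ccc(Oc2ccnc3[nH]ccc23)cc1)c1cn(-c2ccc(F)c(Cl)c2)c2ccccc2c1=O`: in this assay compound 2 gives 4810 nM.
- Compound 3, `Cn1ccc2c(Oc3ccc(NC(=O)c4cn(-c5ccccc5)c5ccccc5c4=O)cc3F)ccnc21`: in this assay compound 3 gives 1720 nM.

Compound 3 holds the second highest of the three numbers. Its gap to compound 1 is within the scatter, so the two cannot be ordered; its gap to compound 2 is beyond the scatter, with compound 2 the higher number.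

Compound 4, `COc1ccc(-n2cc(C(=O)Nc3ccc(Oc4ccnc5c4ccn5C)c(F)c3)c(=O)c3ccccc32)cc1`, differs from compound 3 in one place: methoxy in place of hydrogen on an aromatic carbon. Among the measured compounds shown here, the only measured step that touches the aryl group on the aromatic nitrogen is a 4.7-fold higher number from compound 1 to compound 2 (0.67 log units; beyond the scatter), a modest rise in the number when a substituted phenyl replaced the plain phenyl. For the measured compounds named here, that step concerns a different substituent pattern and bears on the present change only loosely; no measured pair tests methoxy at this place. Going by the values given here, the one precedent points to a weakening, so the expectation for compound 4 in this assay is a small upward step, a 1.5-fold higher number from compound 3 to compound 4 (0.16 log units; within the scatter), that may not clear the scatter. The estimated value for compound 4 is 2500 nM, with a range of 1000 nM to 6500 nM.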

Compound 4, half-maximal inhibitory concentration: 3210 nM
Estimate against measurement, compound 4: 1.3-fold (0.11 log units) below; low and high end bracket the measured number.
By their numbers in this assay, from the lowest: compounds 1, 3, 4 and 2 (each within the scatter of the next, the first and the last beyond it).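

In this assay the change from phenyl to 4-methoxyphenyl gives a 1.9-fold higher number from compound 3 to compound 4 (0.27 log units; within the scatter) so compound 3 and compound 4 cannot be ordered, and a methoxy group para to a large group is accepted at this place without a shift that the assay can resolve. Among the compounds shown here, the only earlier step on this aryl group, a 4.7-fold higher number from compound 1 to compound 2 (0.67 log units; beyond the scatter) for 3-chloro-4-fluorophenyl in place of phenyl, lay beyond the scatter on the core of compound 1, whereas the methoxy step does not; the two steps differ in both substituent and core, so they show only that not every substitution on this ring moves the number by the same amount. No measurement available here bears on why the step has this size.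

From the compounds shown here alone, it remains open whether methoxy would give a similar step on the core of compound 1, where the earlier change was read. Going by these compounds, it also remains open whether a different group at this place, such as an amine, a carboxylic acid or a longer alkoxy chain, would move the number beyond the scatter in either direction.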